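Moving the chlorine on the benzyl group of compound 2

The source may hold more compounds than are shown below. What is called first, only, known or untested is meant among the compounds shown, and "the series" means these compounds.

Compound 2, `COc1ccc(C2N=C(SCc3cccc(Cl)c3)NC(C)=C2C(=O)Nc2ccc(F)cc2)cc1OC`, was tested in a functional assay on the whole organism (artery, strain albino) with Rattus norvegicus as the target, with a stated time of 900 min, at a dose of 10 mg/kg by the oral route (on this read-out higher numbers stand for more inhibition at the one dose given (going by the name of the read-out) and lower numbers for less inhibition), where compound 2 gives 13.3%. This is the higher of the two numbers available: compound 1, `COc1ccc(C2N=C(SCc3ccccc3)NC(C)=C2C(=O)Nc2ccc(F)cc2)cc1OC`, gives 1% in the same test. Among the measured compounds shown here, the only measured step, a number 12.3 percentage points higher from compound 1 to compound 2 (beyond the scatter), shows what adding a chlorine does. Compound 3, `COc1ccc(C2N=C(SCc3ccc(Cl)cc3)NC(C)=C2C(=O)Nc2ccc(F)cc2)cc1OC`, is not yet measured; it differs from compound 2 by 4-chlorophenyl in place of 3-chlorophenyl on a saturated chain carbon bound to a sulfur. For the measured compounds named here, no measured step moves a chlorine from one place on that ring to another, so the change from compound 2 to compound 3 has no direct precedent, and the step of a number 12.3 percentage points higher from compound 1 to compound 2 (beyond the scatter) only sets the scale on which such a ring change acted. Compound 3 is therefore expected to show a step of a number 0.3 percentage points lower from compound 2 to compound 3 (within the scatter), which is within the scatter. Compound 3 is estimated at 13%, between 0% and 28%.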

Compound 3, a percentage reported as inhibition, in the whole organism at one dose (the size of the read-out at that dose, not a potency): 20%
The estimate for compound 3 lay 7 percentage points below the measured number; low and high end bracket the measured number.
By their numbers in this assay, from the lowest: compound 1; then compounds 2 and 3 (each within the scatter of the next).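

In this assay, 4-chlorobenzyl in place of 3-chlorobenzyl gives a small shift (a number 6.7 percentage points higher from compound 2 to compound 3 (within the scatter)), so this read-out does not separate these two placings of the chlorine. Adding chlorine to the plain benzyl group of compound 1 at the newly tested placing also gives a clear step (a number 19 percentage points higher from compound 1 to compound 3 (beyond the scatter)), so among these compounds the effect of chlorine is not confined to the one ring placing seen before. No measurement here offers a reason for either result.

As far as these compounds go, it remains open whether a different group on the benzyl ring, such as a methoxy group or an amine, would act as chlorine does. From the compounds shown here alone, it is also open how a longer chain in place of the benzyl group would fare at this position.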